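The source may report more compounds than this note shows. Statements on the series, on what has been measured and on what is new or still open speak of the compounds shown alone.

Of the compounds shown here, two have so far been tested in a functional assay on MCF7 cells (Homo sapiens) for inhibition, read by CCK-8 assay, with a stated time of 48 h; on this read-out higher numbers stand for weaker inhibition of growth and lower numbers for stronger inhibition of growth. In this assay compound 1 `Cc1ccccc1Nc1nc(Nc2cc(Cl)ccn2)ncc1Cl` gives > 100000 nM, which is a limit of the assay and not a number. Among the compounds with values here, compound 2 `COc1cccc(CNc2nc(Nc3ccc(N4CCN(C)CC4)cn3)ncc2Cl)c1` gives 19500 nM, and this is the only actual number available in this assay, so compound 2 has no measured neighbour to be ranked against on a numerical scale.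

The next compound is compound 3 `CC(C)c1cccc(Nc2nc(Nc3ccc(N4CCN(C)CC4)cn3)ncc2Cl)c1`, which differs from compound 2 in a single place: 3-isopropylphenyl in place of 3-methoxybenzyl on a nitrogen on an aromatic ring. In words, 3-isopropylphenyl stands in place of 3-methoxybenzyl on a nitrogen on an aromatic ring, so that (3-methoxybenzyl)amino becomes (3-isopropylphenyl)amino. Within the data shown here, no measured pair of compounds differs in one place only, so there is no direct precedent for this change, and the expectation is correspondingly loose. A modest move toward stronger inhibition of growth, meaning a lower number, is expected, and the expected step is a 2.4-fold lower number from compound 2 to compound 3 (0.39 log units; beyond the scatter). The estimate for compound 3 is 8000 nM, with an expected range from 1500 nM to 40000 nM.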

Compound 3, concentration for 50% growth inhibition: 8640 nM
Beside the measured number, compound 3's estimate is 1.1-fold (0.03 log units) below it; low and high end bracket the measured number.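

Within the data shown here, the pair gives the first readable step in this assay: with 3-isopropylphenyl in place of 3-methoxybenzyl on a nitrogen on an aromatic ring, the result is a 2.3-fold lower number from compound 2 to compound 3 (0.35 log units; beyond the scatter). This shows that the group on this nitrogen can move the read-out even when the heavy-atom count and the six-membered aromatic ring of carbon stay the same, although the step is modest. Steps to compound 1 cannot be read, as its entry is a limit and not a number: the limit of > 100000 nM in this assay, at which 1 of the 3 values shown sits.

The change alters two things at once, since the benzyl carbon leaves and isopropyl takes the place of methoxy on the ring, so the compounds shown do not tell which of the two carries the step; a 3-methoxyphenyl or a 3-isopropylbenzyl group on the same nitrogen would separate them. Also open, from the compounds shown here alone, is how the number responds to other groups at this position, such as a 3-tert-butylphenyl or a 3-aminophenyl group, and whether any of them would carry the step further in the same direction.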